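Working notes on cytotoxicity: compounds 1, 2 and 3

The source may report more compounds than this note shows. Statements on the series, on what has been measured and on what is new or still open speak of the compounds shown alone.

Measured so far:
- compound 1, `CCCCNc1nc(N)nc2c1ncn2/C=C1/CC1(CO)CO`
- compound 2, `Nc1nc2c(ncn2/C=C2/CC2(CO)CO)c(=O)[nH]1`

Both have been run in an ADME assay on HFF cells (Homo sapiens) for cytotoxicity, with a stated time of 8 days; a higher number here means that more compound is tolerated, a lower number that less compound is tolerated. Compound 1 gives > 300000 nM in this assay, which is a limit of the assay and not a number. Compound 2 likewise gives only a limit, > 300000 nM. Compound 1 thus stands at the limit of > 300000 nM in this assay, at which 2 of the 2 values shown sit, with no numbered value to set it against anything else. Among the compounds with values here, no step between measured compounds that differ in one place is available.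

Compound 3, `Nc1nc(OCc2ccccc2)c2ncn(/C=C3/CC3(CO)CO)c2n1`, has not yet been run in this assay. It differs from compound 1 by benzyloxy in place of butylamino on an aromatic carbon. Within the data shown here, with both values so far sitting at the limit, no step size can be drawn from them, and the expectation for the step of a number no higher from compound 1 to compound 3 (the limit leaves the size open) is one of no change beyond the scatter. Compound 3 is accordingly expected to give about 300000 nM in this assay, within 100000 nM to 1000000 nM, most probably again as a limit rather than a number.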

Compound 3, half-maximal cytotoxic concentration: > 300000 nM
Compound 3 ended at the assay's limit (the forecaster's own chance of this, stated with the estimate: 80%); the middle value sits exactly at the limit.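

Within the data shown here, no step from compound 1 to compound 3 can be read in this assay, as both results are limits of the assay and not numbers: the limit of > 300000 nM in this assay, at which 3 of the 3 values shown sit.

The compounds shown leave open whether benzyloxy in place of butylamino on an aromatic carbon changes cytotoxicity at all.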